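This account rests on a few compounds, and the source may have more. Where it says the series, first, only, none or still open, it means among the compounds named here.

Measured compounds:
compound 1 `COC(=O)[C@@H]1CCCN1C(=O)CCC(=O)Oc1ccc(C[C@H]2C(=O)OC[C@@H]2Cc2ccc(OC)c(OC)c2)cc1OC` – 145000 nM
compound 2 `COc1ccc(C[C@H]2COC(=O)[C@@H]2Cc2ccc(OCc3cn(Cc4ccccc4F)nn3)c(OC)c2)cc1OC` – >= 600000 nM

Within the data shown here, in an ADME assay on HeLa cells (Homo sapiens) for cytotoxicity, read by MTT assay (on this read-out lower numbers stand for stronger inhibition and higher numbers for weaker inhibition), compound 1 gives 145000 nM, the only number in hand. For compound 2 the assay reports a limit, not a number: the limit of >= 600000 nM in this assay, at which 1 of the 2 values shown sits. Compound 1 thus stands alone as a measured value, with nothing to compare it against. Compound 3 `CCN1CCN(C(=O)CCC(=O)Oc2ccc(C[C@H]3C(=O)OC[C@@H]3Cc3ccc(OC)c(OC)c3)cc2OC)CC1` carries one change relative to compound 1: 4-ethylpiperazin-1-yl in place of 2-(methoxycarbonyl)pyrrolidin-1-yl on a carbonyl carbon. Among the measured compounds shown here, no step between measured compounds exists to calibrate this change; the expected step is a 1.4-fold higher number from compound 1 to compound 3 (0.14 log units; within the scatter), likely none beyond the scatter or a modest weakening. Compound 3 is estimated at 200000 nM, within 60000 nM to 600000 nM.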

Compound 3, half-maximal inhibitory concentration: 190000 nM
Compound 3: middle estimate off by 1.1-fold (0.02 log units), on the high side; measured number inside the range.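

In this assay, the carbonyl carbon now has its first calibrated exchange: a 1.3-fold higher number from compound 1 to compound 3 (0.12 log units; within the scatter). At this position, the five-membered 2-(methoxycarbonyl)pyrrolidin-1-yl, with its defined stereocentre, gives way to the six-membered 4-ethylpiperazin-1-yl without a shift beyond the scatter, so this pair tolerates the exchange, though a single pair sets no trend.

Going by these compounds, whether a carboxylic acid, a primary amine or a longer chain on this carbonyl carbon would move the read-out remains open. Compound 2 gives a limit, not a number: the limit of >= 600000 nM in this assay, at which 1 of the 3 values shown sits.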